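One Group Exchanged on an Amide at the Assay Limit

This account rests on a few compounds, and the source may have more. Where it says the series, first, only, none or still open, it means among the compounds named here.

In a functional assay on A2780 cells (Homo sapiens) for inhibition, read by sulforhodamine B assay, with a stated time of 72 h (on this read-out lower numbers stand for stronger inhibition and higher numbers for weaker inhibition), compound 1 `O=C(NCc1ccc(S(=O)(=O)c2ccccc2)cc1)c1nc2ccncc2s1` gives > 10000 nM, which is a limit of the assay and not a number. Compound 1 thus stands at the limit of > 10000 nM in this assay, at which 2 of the 2 values shown sit. Compound 2 `Cn1c(C(=O)NCc2ccc(S(=O)(=O)c3ccccc3)cc2)cc2cnccc21` gives > 10000 nM, which is likewise a limit. Among the compounds with values here, neither compound offers a number, and no measured step connects any of the compounds.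

Compound 3 `O=C(NCc1ccc(S(=O)(=O)c2ccccc2)cc1)c1c[nH]c2ccncc12` keeps the amide and the rest of compound 1 but exchanges the group on the carbonyl carbon: a group of 9 heavy atoms (7 carbon, 2 nitrogen; one five-membered aromatic ring with 1 hetero atom, one six-membered aromatic ring with 1 hetero atom) in place of a group of 9 heavy atoms (6 carbon, 2 nitrogen, 1 sulfur; one five-membered aromatic ring with 2 hetero atoms, one six-membered aromatic ring with 1 hetero atom), on a carbonyl carbon. In this assay, any number for compound 3 is expected to point towards stronger inhibition, though the assay may again report only a limit. The expected size is an at least 1.6-fold lower number from compound 1 to compound 3 (0.22 log units; that floor lies within the scatter), an estimate with wide uncertainty. For compound 3, the estimated value is 6000 nM, with an expected range from 500 nM to 15000 nM.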

Compound 3, half-maximal inhibitory concentration: 2100 nM
Beside the measured number, compound 3's estimate is 2.9-fold (0.46 log units) above it; measured number inside the range.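

In this assay compound 3 is the first of the compounds shown to give a number and not a limit, while the other two stay at that limit: the limit of > 10000 nM in this assay, at which 2 of the 3 values shown sit. Exchanging the group on the carbonyl carbon gives an at least 4.7-fold lower number from compound 1 to compound 3 (0.67 log units; beyond the scatter), and as compound 1 has only a limit, this size is a floor, so the true step could be larger. This position therefore responds to a change of group, and the amide and the rest of the molecule need not change for a number to appear.

The step cannot tell whether the sulfur leaving or the hydrogen-bond donor entering carries this difference. As far as these compounds go, how a carboxylic acid, an amine or a plain phenyl group would fare on the same carbonyl carbon remains open.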